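Amide changes in the series: compound 2 to compound 3

This account rests on a few compounds, and the source may have more. Where it says the series, first, only, none or still open, it means among the compounds named here.

- compound 1 (`C[C@H](Nc1ncnc(N)c1C#N)c1nc2ccc(F)cc2c(C(N)=O)c1-c1ccccc1`) : < 14 mL.min-1.g-1
- compound 2 (`CNC(=O)c1c(-c2ccccc2)c([C@H](C)Nc2ncnc(N)c2C#N)nc2ccc(F)cc12`) : < 14 mL.min-1.g-1

In an ADME assay on microsomes from liver (Homo sapiens) for pharmacokinetics, using NADPH, with a stated time of 30 min, tested at 1 uM (a higher number here means faster removal of the compound, a lower number slower removal), compound 2 gives < 14 mL.min-1.g-1, which is a limit and not a number. Compound 3 (`C[C@H](Nc1ncnc(N)c1C#N)c1nc2ccc(F)cc2c(C(=O)N2CC(O)C2)c1-c1ccccc1`) differs from compound 2 as follows: 3-hydroxyazetidin-1-yl in place of methylamino on a carbonyl carbon, with 3-hydroxyazetidin-1-yl in place of methylamino on a carbonyl carbon. Among the measured compounds shown here, the one measured step on this amide is a step that the two limits leave unreadable from compound 1 to compound 2, so it supplies no size to carry over. No change beyond the scatter is therefore expected in this assay, and the expected step is a step that the limit leaves unreadable from compound 2 to compound 3. For compound 3 the estimated value is 11 mL.min-1.g-1, with an expected range of 6 mL.min-1.g-1 to 24 mL.min-1.g-1.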

Compound 3, intrinsic clearance in microsomes: 40 mL.min-1.g-1
Compound 3: middle estimate off by 3.6-fold (0.56 log units), on the low side; the measured number lies above the stated range.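

In this assay, 3-hydroxyazetidin-1-yl on the carbonyl carbon gives an at least 2.8-fold higher number from compound 2 to compound 3 (0.45 log units; beyond the scatter), and against the primary amide it gives an at least 2.8-fold higher number from compound 1 to compound 3 (0.45 log units; beyond the scatter). Among the compounds shown here, this is the first readable change at this position, and it shows that the group on the carbonyl carbon can move the clearance in microsomes to a higher number. The step from compound 1 to compound 2 cannot be read: the limit of < 14 mL.min-1.g-1 in this assay, at which 2 of the 3 values shown sit.

Which part of 3-hydroxyazetidin-1-yl goes with the higher number stays open. Unsubstituted azetidin-1-yl or a 2-hydroxyethylamino chain on the same carbonyl carbon would separate the ring from the hydroxyl.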